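The source may report more compounds than this note shows. Statements on the series, on what has been measured and on what is new or still open speak of the compounds shown alone.

Compound 1 `CCN(CC)CC(=O)Nc1ccc(-c2nc3cc(C(F)(F)F)ccc3[nH]2)cc1` gives 24000 nM in an ADME assay on Vero cells (Chlorocebus sabaeus) for cytotoxicity; on this read-out higher numbers stand for lower toxicity in this test and lower numbers for higher toxicity in this test.
Compound 2 `Fc1ccc(-c2nc3cc(C(F)(F)F)ccc3[nH]2)cc1` gives 60000 nM in this assay.

Compound 2 holds the highest of the two numbers measured in this assay, with compound 1 nearest, a 2.5-fold higher number from compound 1 to compound 2 (0.40 log units; beyond the scatter). Compound 3 `O=C(CCl)Nc1ccc(-c2nc3cc(C(F)(F)F)ccc3[nH]2)cc1` is not yet measured and differs from compound 2 by ((chloromethyl)carbonyl)amino in place of fluoro on an aromatic carbon. Among the compounds with values here, only one measured step bears on this change, the one from compound 1 to compound 2, in which an acylamino group gave way to fluoro and the number rose by a modest but real amount, a 2.5-fold higher number from compound 1 to compound 2 (0.40 log units; beyond the scatter). The change to compound 3 brings an acylamino group back in place of fluoro, so an expectation of the reverse seems reasonable: a modest drop, roughly mirroring that step. Compound 3 is therefore expected to show a 2.4-fold lower number from compound 2 to compound 3 (0.38 log units; beyond the scatter), estimated at 25000 nM with a range of 10000 nM to 60000 nM.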

Compound 3, half-maximal cytotoxic concentration: 35000 nM
The estimate for compound 3 lay 1.4-fold (0.15 log units) below the measured number; the range from low to high includes it.
By their numbers in this assay, from the lowest: compounds 1, 3 and 2 (each within the scatter of the next, the first and the last beyond it).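

In this assay, the step with ((chloromethyl)carbonyl)amino in place of fluoro, on an aromatic carbon para to a large group, comes to a 1.7-fold lower number from compound 2 to compound 3 (0.23 log units; within the scatter) and so does not separate these two groups at this position. On the chain, chloro in place of diethylamino gives a 1.5-fold higher number from compound 1 to compound 3 (0.16 log units; within the scatter) and so does not separate these two compounds either. Compound 3 thus lies within the scatter of both neighbours, and the earlier gap beyond the scatter cannot be read as belonging to every acylamino group at this position; no evidence here explains these numbers.

The compounds shown leave open whether a free amine or a carboxylic acid at this position would stay within the scatter of fluoro. They also leave open how a longer chain on the carbonyl would read in this test.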